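The compounds below may be only part of what the source reports. "The series", "measured", "known", "first", "only" and "open" are said of these compounds alone.

Compound 2 `COc1cc(C(=O)NC2CCN(C)CC2)ccc1Nc1ncc(Br)c(NC2CCCC2)n1` stands second highest of the three numbers in a functional assay on HCT-8 cells (Homo sapiens) for cytotoxicity, read by MTT assay, with a stated time of 48 h (a lower number here means a stronger inhibitor, a higher number a weaker inhibitor), where compound 2 gives 12000 nM. Compound 1 `CN1CCN(c2ccc(Nc3ncc(F)c(NC4CCCC4)n3)cc2)CC1` gives 29000 nM, and compound 3 `CN1CCC(NC(=O)c2ccc(Nc3ncc(Br)c(NC4CCCC4)n3)cc2)CC1` gives 3600 nM. Among the compounds with values here, the only single-place step measured is a 3.3-fold lower number from compound 2 to compound 3 (0.52 log units; beyond the scatter), and it concerns the methoxy, not the halogen. Compound 4 `COc1cc(C(=O)NC2CCN(C)CC2)ccc1Nc1ncc(F)c(NC2CCCC2)n1` differs from compound 2 by fluoro in place of bromo on an aromatic carbon. Within the data shown here, no measured pair isolates this exchange; compound 1, carrying the fluoro, and compound 3, carrying the bromo, differ in more than one place, so their values show only that the fluoro compound gives the higher number in this assay. Compound 4 is therefore expected to show a somewhat higher number, by a 2.1-fold higher number from compound 2 to compound 4 (0.32 log units; beyond the scatter). The estimate for compound 4 is 25000 nM, between 8000 nM and 80000 nM.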

Compound 4, half-maximal inhibitory concentration: 2100 nM
Beside the measured number, compound 4's estimate is 12-fold (1.08 log units) above it; measured number below the stated range.
By their numbers in this assay, from the lowest: compounds 4 and 3 (each within the scatter of the next); then compound 2; then compound 1.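

In this assay, within the data shown here, the exchange of bromo for fluoro on this aromatic carbon, ortho to a cyclopentylamino group, gives a 5.7-fold lower number from compound 2 to compound 4 (0.76 log units; beyond the scatter) and so provides the first single-place reading of the halogen. At this position, with the methoxy and the amide side chain held constant, the fluoro compound has the lower number, beyond the scatter. Nothing available here accounts for this difference.

Going by these compounds, it remains open whether the same exchange would give a similar step in compound 3, which carries no methoxy. On these data alone, how chloro, methyl or nitrile at this position would compare also remains open.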